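The source may hold more compounds than are shown below. What is called first, only, known or untested is meant among the compounds shown, and "the series" means these compounds.

Measured so far:
Compound 1 `C=CCn1ncc2c(CC)ncn2c1=O`. In a functional assay for inhibition, with Homo sapiens as the target (a higher number here means a weaker inhibitor, a lower number a stronger inhibitor), compound 1 gives only a limit, > 48000 nM.
Compound 2 `C=CCn1ncc2c(CCC)ncn2c1=O`. In this assay compound 2 gives only a limit, > 48000 nM.
Compound 3 `CCCc1nc(C)c2c(C(C)C)cnc(Nc3cc[nH]n3)n12`. In this assay compound 3 gives only a limit, > 48000 nM.

Compounds 1 and 2 share one core; compound 3 has another, and the difference between the two cores is not broken down here. From compound 2 to compound 1 the change is hydrogen in place of methyl on a saturated chain carbon, two bonds along the chain from an aromatic carbon, and the step is a step that the two limits leave unreadable from compound 2 to compound 1. Compound 4 `CCCc1nc(C)c2c(CC)cnc(Nc3cc[nH]n3)n12` is not yet measured; from compound 3 it differs by hydrogen in place of methyl on a saturated chain carbon bound to an aromatic carbon and a saturated chain carbon. This is the same kind of change, not the same: in compound 2 the carbon that loses the methyl lies two bonds along the chain from an aromatic carbon, in compound 3 it is bound to an aromatic carbon and a saturated chain carbon. All three values sit at the limit of > 48000 nM in this assay, at which 3 of the 3 values shown sit, which leaves no readable step to lean on. For compound 4 the step that the limit leaves unreadable from compound 3 to compound 4 is expected to be near zero, resting on (the limit of > 48000 nM in this assay, at which 3 of the 3 values shown sit). The estimate for compound 4 is 60000 nM, most likely again reported only as a limit, expected between 15000 nM and 200000 nM.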

Compound 4, half-maximal inhibitory concentration: > 48000 nM
Compound 4: a limit, no number; the forecaster's own chance of this, stated with the estimate: 85%; the middle value does not contradict the limit.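

Compound 3 and compound 4 both give only limits in this assay, so the step between them cannot be read: the limit of > 48000 nM in this assay, at which 4 of the 4 values shown sit.

The compounds shown leave open how these four compare in inhibition and whether isopropyl to ethyl changes it at all.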